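Hydroxy to 2-methoxy-2-methylpropoxy: a half-life step in question

The compounds below may be only part of what the source reports. "The series", "measured", "known", "first", "only" and "open" are said of these compounds alone.

Compound 1 `COc1cc2c(Oc3ccc(Nc4nccc5[nH]cc(-c6ccc(F)cc6)c(=O)c45)cc3F)ccnc2cc1OCCO`: 1.48 h
Compound 2 `COCCOc1cc2nccc(Oc3ccc(Nc4nccc5[nH]cc(-c6ccc(F)cc6)c(=O)c45)cc3F)c2cc1OC`: 1.06 h
Compound 3 `O=c1c(-c2ccc(F)cc2)c[nH]c2ccnc(Nc3ccc(Oc4ccnc5cc(O)ccc45)c(F)c3)c12`: 0.893 h

In an ADME assay on microsomes from liver (Rattus norvegicus) for metabolic stability (on this read-out higher numbers stand for a longer-lived compound and lower numbers for a shorter-lived compound), compound 3 gives 0.893 h and lies within the scatter of the other two compounds. Compound 4 `COC(C)(C)COc1ccc2c(Oc3ccc(Nc4nccc5[nH]cc(-c6ccc(F)cc6)c(=O)c45)cc3F)ccnc2c1` differs from it by 2-methoxy-2-methylpropyl in place of hydrogen on an oxygen on an aromatic ring with 2-methoxy-2-methylpropyl in place of hydrogen on an oxygen on an aromatic ring. Going by the values given here, only one measured step bears on this, and only loosely: a 1.4-fold lower number from compound 1 to compound 2 (0.14 log units; within the scatter) with methyl in place of hydrogen on an oxygen on a saturated carbon. That step sits at a different place and is a smaller change. No step beyond the scatter is therefore expected, in either direction (a 1.1-fold higher number from compound 3 to compound 4 (0.05 log units; within the scatter)). Compound 4 is estimated at 1 h (range 0.4 h to 2.4 h).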

Compound 4, half-life: 1.45 h
The estimate for compound 4 lay 1.5-fold (0.16 log units) below the measured number; measured number inside the range.
By their numbers in this assay, from the lowest: compounds 3, 2, 4 and 1 (each within the scatter of the next).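

In this assay the hydroxy to 2-methoxy-2-methylpropoxy change gives a 1.6-fold higher number from compound 3 to compound 4 (0.21 log units; within the scatter) and so shows that this oxygen on an aromatic ring can carry the whole 2-methoxy-2-methylpropyl group without a step beyond the scatter. Going by these compounds alone, the one earlier step lay on an oxygen on a saturated carbon and said nothing about this place. No available measurement explains the result. Open, going by these compounds, is whether a chain bearing an amine or a carboxylic acid in place of 2-methoxy-2-methylpropyl would also stay within the scatter.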